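The source may report more compounds than this note shows. Statements on the series, on what has been measured and on what is new or still open speak of the compounds shown alone.

Measured in a functional assay on SGC-7901 cells (Homo sapiens) for antiproliferative activity, read by MTT assay, with a stated time of 72 h; on this read-out lower numbers stand for stronger inhibition and higher numbers for weaker inhibition:
- Compound 1 `COc1cc(-n2cnc3ccc(-c4ccccc4Cl)cc32)cc(OC)c1OC`: > 10000 nM, a limit of the assay and not a number.
- Compound 2 `COc1cc(-n2cnc3ccc(-c4ccc(C)cc4F)cc32)cc(OC)c1OC`: 5650 nM.
- Compound 3 `COc1cc(-n2cnc3ccc(-c4cc(F)ccc4F)cc32)cc(OC)c1OC`: 6590 nM.

Only two of the three results are numbers, and they lie together: a 1.2-fold higher number from compound 2 to compound 3 (0.07 log units; within the scatter). Compound 3 therefore stands level with compound 2 in this assay.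

Compound 4 `COc1cc(-n2cnc3ccc(-c4ccc(C(F)(F)F)cc4)cc32)cc(OC)c1OC` carries 4-(trifluoromethyl)phenyl in place of 2,5-difluorophenyl on an aromatic carbon of the shared core (4-(trifluoromethyl)phenyl in place of 2,5-difluorophenyl on an aromatic carbon). All three measured steps change the group at this same place. The closest guide is the exchange of one substituted phenyl group for another: a 1.2-fold higher number from compound 2 to compound 3 (0.07 log units; within the scatter). The other two steps start from a limit and give only floors: an at least 1.7-fold lower number from compound 1 to compound 2 (0.24 log units; that floor lies within the scatter) and an at least 1.5-fold lower number from compound 1 to compound 3 (0.18 log units; that floor lies within the scatter). Within the data shown here, no measured compound carries a trifluoromethyl group, so the range has to stay wide.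

No step beyond the scatter is expected in either direction, and the expected step is a 1.1-fold higher number from compound 3 to compound 4 (0.03 log units; within the scatter). A result reported only as a limit remains possible. For compound 4 the estimated value is 7000 nM, with an expected range from 3000 nM to 15000 nM.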

Compound 4, half-maximal inhibitory concentration: 890 nM
Estimate against measurement, compound 4: 7.9-fold (0.90 log units) above; measured number outside the range, below it.
By their numbers in this assay, from the lowest: compound 4; then compounds 2 and 3 (each within the scatter of the next). At a limit, above all of these: compound 1.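

In this assay, this place on the shared core proves able to move the read-out well beyond the scatter, which the earlier numbers did not show: a 7.4-fold lower number from compound 3 to compound 4 (0.87 log units; beyond the scatter) and a 6.3-fold lower number from compound 2 to compound 4 (0.80 log units; beyond the scatter). Compound 1 gives > 10000 nM, a limit of the assay and not a number. The step to 4-(trifluoromethyl)phenyl can be read only as a floor, an at least 11-fold lower number from compound 1 to compound 4 (1.05 log units; beyond the scatter), and it rests on a single limit: the limit of > 10000 nM in this assay, at which 1 of the 4 values shown sits.

Of the four aryl groups shown, 4-(trifluoromethyl)phenyl is the only one named without a substituent at the 2-position, so the compounds shown do not separate the effect of the trifluoromethyl group from that of having no 2-substituent, and compound 2, with its 4-methyl group and 2-fluoro group, gives only one partial comparison. Whether an unsubstituted phenyl, a 4-methoxyphenyl, a 4-aminophenyl or a phenyl carrying a carboxylic acid at the 4-position would follow compound 4 stays open, as does any reason for the step.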